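Enlarging the amino position of compound 2

The compounds below may be only part of what the source reports. "The series", "measured", "known", "first", "only" and "open" are said of these compounds alone.

In an ADME assay on CHO cells (Cricetulus griseus) for cytotoxicity, read by MTT assay (a higher number here means that more compound is tolerated, a lower number that less compound is tolerated), compound 1 (`CN1CCN(c2nccc3nc(-c4ccc(F)c(F)c4)[nH]c23)CC1`) gives 50000 nM and compound 2 (`NC1CCN(c2nccc3[nH]c(-c4cccc(OC(F)(F)F)c4)nc23)CC1`) gives 42000 nM with the two values within the scatter of each other. These two compounds differ in more than one place, so they do not isolate the effect of any single change. Compound 3 (`CN1CCN(CC2CCN(c3nccc4[nH]c(-c5cccc(OC(F)(F)F)c5)nc34)CC2)CC1`) has (4-methylpiperazin-1-yl)methyl in place of the amino group of compound 2 on a saturated ring carbon ((4-methylpiperazin-1-yl)methyl in place of amino on a saturated ring carbon). Among the compounds with values here, no measured pair shows a step at this place, so the expectation in this assay has no direct precedent. A modest step towards a lower number is expected, although a result within the scatter would not be surprising. The estimated change is a 1.7-fold lower number from compound 2 to compound 3 (0.23 log units; within the scatter) on this reading. Compound 3 is estimated at 25000 nM with a range from 9000 nM to 55000 nM in this measurement.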

Compound 3, half-maximal cytotoxic concentration: 950 nM
Compound 3: middle estimate off by 26-fold (1.42 log units), on the high side; the whole stated range lies above it.
By their numbers in this assay, from the lowest: compound 3; then compounds 2 and 1 (each within the scatter of the next).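

In this assay, within the data shown here, the step from amino to (4-methylpiperazin-1-yl)methyl on this saturated ring carbon is the only single-place change, and it gives a 44-fold lower number from compound 2 to compound 3 (1.65 log units; beyond the scatter). Compound 1 and compound 2 differ in more than one place, so their values could not show that this position responds to a change of group. The step comes with a larger group, 8 heavy atoms in place of 1 and a new six-membered non-aromatic ring, but nothing measured here explains it.

Open, on these data alone, is whether the step belongs to the whole (4-methylpiperazin-1-yl)methyl group or to a part of it: an aminomethyl group or a dimethylamino group on the same carbon would help separate these. Also open, as far as these compounds go, is whether the same change gives a similar step with the other groups of compound 1.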